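This account rests on a few compounds, and the source may have more. Where it says the series, first, only, none or still open, it means among the compounds named here.

The three measured compounds share one core and differ at a single position. Compound 1 `O=C(Nn1c(-c2cccc([N+](=O)[O-])c2)nc2c(-c3ccc(Cl)cc3)n[nH]c2c1=O)c1ccccc1` carries a 3-nitrophenyl there, compound 2 `O=C(Nn1c(-c2ccccc2)nc2c(-c3ccc(Cl)cc3)n[nH]c2c1=O)c1ccccc1` a phenyl, and compound 3 `COc1cccc(Cc2nc3c(-c4ccc(Cl)cc4)n[nH]c3c(=O)n2NC(=O)c2ccccc2)c1` a 3-methoxybenzyl. In a functional assay on DU-145 cells (Homo sapiens) for inhibition, read by MTT assay, with a stated time of 2 days (on this read-out lower numbers stand for stronger inhibition of growth and higher numbers for weaker inhibition of growth), compound 1 gives 17100 nM, compound 2 gives 20100 nM, and compound 3 gives 44900 nM, the highest number of the three: the steps of a 2.6-fold higher number from compound 1 to compound 3 (0.42 log units; beyond the scatter) and a 2.2-fold higher number from compound 2 to compound 3 (0.35 log units; beyond the scatter) both lie beyond the scatter, whereas the step of a 1.2-fold higher number from compound 1 to compound 2 (0.07 log units; within the scatter) does not.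

Compound 4 `O=C(Nn1c(CCc2ccccc2)nc2c(-c3ccc(Cl)cc3)n[nH]c2c1=O)c1ccccc1` has not yet been measured. It differs from compound 3 by benzyl in place of 3-methoxyphenyl on a saturated chain carbon bound to an aromatic carbon; the same difference, cut one bond further out, reads 3-methoxybenzyl to phenethyl. Among the compounds with values here, two measured steps bear on this. The step of a 2.2-fold higher number from compound 2 to compound 3 (0.35 log units; beyond the scatter) shows that moving from phenyl to 3-methoxybenzyl raised the number modestly, and the step of a 1.2-fold higher number from compound 1 to compound 2 (0.07 log units; within the scatter) shows that removing the nitro changed little. A longer chain without the methoxy is therefore expected to give only a small step, a 1.2-fold higher number from compound 3 to compound 4 (0.09 log units; within the scatter), toward a higher number or none beyond the scatter. Compound 4 is accordingly estimated at 55000 nM, within a range from 22000 nM to 140000 nM.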

Compound 4, concentration for 50% growth inhibition: 86700 nM
Compound 4: middle estimate off by 1.6-fold (0.20 log units), on the low side; the measured number falls inside the stated range.
By their numbers in this assay, from the lowest: compounds 1 and 2 (each within the scatter of the next); then compounds 3 and 4 (each within the scatter of the next).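

In this assay, the step of a 1.9-fold higher number from compound 3 to compound 4 (0.29 log units; within the scatter) lies within the scatter, so 3-methoxybenzyl and phenethyl cannot be told apart at this position. The new compound sharpens a pattern that compound 3 alone could only suggest: a 4.3-fold higher number from compound 2 to compound 4 (0.63 log units; beyond the scatter) and a 5.1-fold higher number from compound 1 to compound 4 (0.71 log units; beyond the scatter) both lie beyond the scatter, and among these four compounds, the two with a saturated chain carbon bound to the aromatic carbon of the core, compound 3 and compound 4, both give higher numbers than compound 1 and compound 2, whose aromatic rings sit directly on that carbon, with no compound going against this. Nothing available here explains why the numbers differ in this way.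

The compounds shown leave open how a plain benzyl group or a longer chain such as 3-phenylpropyl would read at this position, and so whether chain length alone tracks with the number. They also leave open whether a methoxy group on the ring of the phenethyl, or an amine or a carboxylic acid in its place, would shift the number beyond the scatter.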